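This account rests on a few compounds, and the source may have more. Where it says the series, first, only, none or still open, it means among the compounds named here.

Working notes on the series. Compound 1 `O=C(Nc1cc(F)c(F)c(F)c1)N1Cc2c(-c3ccc(F)cc3F)cnn2CC1C1CC1` in a toxicity assay on HepG2 2.2.15 cells (Homo sapiens) for cytotoxicity, read by CellTiter-Glo (on this read-out higher numbers stand for lower toxicity in this test and lower numbers for higher toxicity in this test), gives 32100 nM. Compound 2 `O=C1CC(c2ccccc2)CN1c1cnn2c1CN(C(=O)Nc1cc(F)c(F)c(F)c1)C(C1CC1)C2` in this assay gives 12800 nM, and compound 3 `O=C1CC(c2nccs2)CN1c1cnn2c1CN(C(=O)Nc1cc(F)c(F)c(F)c1)C(C1CC1)C2` in this assay gives 115000 nM. Compound 3 stands highest of the three numbers: a 3.6-fold higher number from compound 1 to compound 3 (0.55 log units; beyond the scatter) and a 9.0-fold higher number from compound 2 to compound 3 (0.95 log units; beyond the scatter), both beyond the scatter. Compound 4 `O=C(Nc1cc(F)c(F)c(F)c1)N1Cc2c(-c3ccc(F)cc3)cnn2CC1C1CC1` has not yet been measured. It differs from compound 3 in one place: 4-fluorophenyl in place of 2-oxo-4-(1,3-thiazol-2-yl)pyrrolidin-1-yl on an aromatic carbon. The step that bears most directly on this change is a 3.6-fold higher number from compound 1 to compound 3 (0.55 log units; beyond the scatter), since compound 1 also carries a fluorinated phenyl at this aromatic carbon; the change to compound 4 essentially reverses that step, with one fluorine fewer on the phenyl. The step of a 2.5-fold lower number from compound 1 to compound 2 (0.40 log units; beyond the scatter) shows that the two pyrrolidinone variants sit on either side of compound 1. A modest step downward is therefore expected for compound 4, a 3.8-fold lower number from compound 3 to compound 4 (0.58 log units; beyond the scatter), landing near the number of compound 1. Compound 4 is expected to give 30000 nM, within a range of 12000 nM to 80000 nM.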

Compound 4, half-maximal cytotoxic concentration: 38500 nM
Beside the measured number, compound 4's estimate is 1.3-fold (0.11 log units) below it; the measured number falls inside the stated range.
By their numbers in this assay, from the lowest: compound 2; then compounds 1 and 4 (each within the scatter of the next); then compound 3.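

In this assay, a 1.2-fold higher number from compound 1 to compound 4 (0.08 log units; within the scatter), so hydrogen in place of fluoro on the phenyl at this aromatic carbon leaves the number within the scatter, and this one fluorine shows no measurable weight here. Exchange of a 2-oxopyrrolidin-1-yl group for 4-fluorophenyl has no single direction: a 3.0-fold lower number from compound 3 to compound 4 (0.48 log units; beyond the scatter) when 2-oxo-4-(1,3-thiazol-2-yl)pyrrolidin-1-yl leaves, whereas a 3.0-fold higher number from compound 2 to compound 4 (0.48 log units; beyond the scatter) when 2-oxo-4-phenylpyrrolidin-1-yl leaves, so the outcome depends on the substituent carried by the pyrrolidinone and not on the pyrrolidinone alone. Nothing in the data at hand accounts for these shifts.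

The compounds shown leave open how far the number moves with a non-aromatic group at this aromatic carbon, such as an amine or a carboxylic acid. They also leave open whether a pyridine ring in place of the thiazole on the pyrrolidinone would follow compound 3 or compound 2.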